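The source may hold more compounds than are shown below. What is called first, only, known or untested is meant among the compounds shown, and "the series" means these compounds.

Measured so far in an ADME assay on MCF-10A cells (Homo sapiens) for antiproliferative activity, read by sulforhodamine B assay, with a stated time of 48 h; a higher number here means a weaker inhibitor of growth, a lower number a stronger inhibitor of growth:

Compound 1, `CN1CCN(CCCNc2ccnc3cc(Cl)ccc23)CC1`, gives 16700 nM.
Compound 2, `O=C1C(=O)N(CCCNc2ccnc3cc(Cl)ccc23)c2ccccc21`, gives 35900 nM.
Compound 3, `CN1CCN(CCCNc2ccnc3cc(C(F)(F)F)ccc23)CC1`, gives 51700 nM.

Compound 1 and compound 2 share the same outer part but carry different cores; the difference between the two cores is not broken down here. Compound 3 is made from compound 1 by one change, (trifluoromethyl in place of chloro on an aromatic carbon), and this step gave a 3.1-fold higher number from compound 1 to compound 3 (0.49 log units; beyond the scatter).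

The unmeasured compound 4, `O=C1C(=O)N(CCCNc2ccnc3cc(C(F)(F)F)ccc23)c2ccccc21`, arises from compound 2 by trifluoromethyl in place of chloro on an aromatic carbon, which is the same change at the same place. Within the data shown here, since the only example of this change, the step from compound 1 to compound 3, moved the number upward, compound 4 is expected to follow it, which would mean a 2.4-fold higher number from compound 2 to compound 4 (0.37 log units; beyond the scatter), with the wider spread of the other core left open. The estimate for compound 4 in this assay is 85000 nM, between 35000 nM and 200000 nM.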

Compound 4, concentration for 50% growth inhibition: 46800 nM
The estimate for compound 4 lay 1.8-fold (0.26 log units) above the measured number; the measured number falls inside the stated range.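

In this assay, trifluoromethyl in place of chloro on the core of compound 2 gives a 1.3-fold higher number from compound 2 to compound 4 (0.12 log units; within the scatter), so on this core the change leaves no effect that can be told from ordinary repeat variation. The two steps cannot be told apart, which means nothing here shows the change behaving differently on the two cores: the same change on two cores in this assay, a 3.1-fold higher number (0.49 log units; beyond the scatter) from compound 1 to compound 3 and a 1.3-fold higher number (0.12 log units; within the scatter) from compound 2 to compound 4, 2.4-fold (0.38 log units) apart, within the scatter of two such steps This does not prove that the step has the same size on both, since only two pairs are shown, one beyond the scatter and one within it, and it says nothing about any other core.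

The compounds shown leave open how a bromo group, a methoxy group or a nitrile would behave at the same place. They also leave open whether a longer chain would change the size of this step.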